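Adding a Methyl to the Anilide Ring of Compound 2

A few compounds are considered here, and "the series" means these few. Any claim that something is new, unique, unknown or untested is made for them only; others in the source may bear on it.

Measured so far:
- compound 1, `COc1cc2c(Nc3nc4ccc(C(=O)Nc5c(C)cc(C)cc5C)cc4s3)ncnc2cc1OCCCN1CCC(C)CC1`: 7700 nM
- compound 2, `COc1cc2c(Nc3nc4ccc(C(=O)Nc5c(C)cccc5C)cc4s3)ncnc2cc1OCCCN1CCCCC1C`: 84400 nM

In a functional assay on NCI-H661 cells (Homo sapiens) for cytotoxicity, read by WST assay, with a stated time of 72 h (on this read-out lower numbers stand for stronger inhibition and higher numbers for weaker inhibition), compound 2 gives 84400 nM, the higher of the two numbers measured. Compound 1 gives 7700 nM, a value that lies below that of compound 2 by more than the usual scatter; the two compounds differ in more than one place, so only their values can be compared. Compound 3, `COc1cc2c(Nc3nc4ccc(C(=O)Nc5c(C)cc(C)cc5C)cc4s3)ncnc2cc1OCCCN1CCCCC1C`, differs from compound 2 by methyl in place of hydrogen on an aromatic carbon. The change gives compound 3 the (2,4,6-trimethylphenyl)carbamoyl group found in compound 1 while keeping the rest of compound 2 unchanged. Among the measured compounds shown here, no single-change step between measured compounds is available, so the size of the effect is open, but compound 3 is expected to move toward compound 1, with an estimated step of a 3.4-fold lower number from compound 2 to compound 3 (0.53 log units; beyond the scatter). For compound 3 the value in this assay is estimated at 25000 nM, expected to fall between 8000 nM and 80000 nM.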

Compound 3, half-maximal inhibitory concentration: 8800 nM
For compound 3 the middle estimate is 2.8-fold (0.45 log units) above the measured one; the measured number falls inside the stated range.
By their numbers in this assay, from the lowest: compounds 1 and 3 (each within the scatter of the next); then compound 2.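

In this assay, among the compounds shown here, methyl in place of hydrogen on the aromatic carbon para to a large group, which turns 2,6-dimethylphenyl into 2,4,6-trimethylphenyl, gives a 9.6-fold lower number from compound 2 to compound 3 (0.98 log units; beyond the scatter), the first single-change reading at this position and one beyond the scatter. With 2,4,6-trimethylphenyl in place, 2-methylpiperidin-1-yl instead of 4-methylpiperidin-1-yl on the chain gives a 1.1-fold higher number from compound 1 to compound 3 (0.06 log units; within the scatter), which lies within the scatter, so the two piperidines cannot be told apart in this setting. Nothing shown here accounts for the effect of the added methyl. On these data alone, whether a chlorine, a methoxy or an ethyl on the same aromatic carbon would act as the methyl does remains open. Also open, as far as these compounds go, is whether the methyl step would hold with 4-methylpiperidin-1-yl on the chain, or with an unsubstituted piperidine or a morpholine.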